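Pyrazine hydrazones: trading a phenolic hydroxy for isopropyl

This account rests on a few compounds, and the source may have more. Where it says the series, first, only, none or still open, it means among the compounds named here.

Compounds measured so far:
compound 1 `COc1cc(/C=N/NC(=O)c2cnccn2)ccc1O`, 63.5%
compound 2 `O=C(N/N=C/c1ccc(O)cc1)c1cnccn1`, 42.3%
compound 3 `COc1ccc(/C=N/NC(=O)c2cnccn2)cc1OC`, 49.6%

Three hydrazones sharing the same core were tested in a functional assay on the whole organism (strain Swiss) for inhibition, with Mus musculus as the target, read by paw edema, with stated times of 40 min and 30 min, at a dose of 100 umol/kg by the oral route; on this read-out lower numbers stand for less inhibition and higher numbers for more inhibition at the one dose given (going by the name of the read-out). Compound 1 gives 63.5%, compound 2 gives 42.3% and compound 3 gives 49.6%. Compound 2 has the lowest of the three numbers; its gap to compound 3 lies within the scatter, while compound 1 stands beyond it, as a number 21.2 percentage points lower from compound 1 to compound 2 (beyond the scatter) shows. The other measured step, a number 13.9 percentage points lower from compound 1 to compound 3 (beyond the scatter), also runs downward.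

Compound 4 `CC(C)c1ccc(/C=N/NC(=O)c2cnccn2)cc1` is unmeasured. It differs from compound 2 by isopropyl in place of hydroxy on an aromatic carbon. For the measured compounds named here, no measured step covers this exchange directly; the two steps known both involve oxygen-bearing groups on the aromatic ring, and both lowered the read-out modestly. Removing the last such group from compound 2 is therefore expected to give a small further drop or no change beyond the scatter, a number 7.3 percentage points lower from compound 2 to compound 4 (within the scatter). Compound 4 is estimated at 35%, within 15% to 55%.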

Compound 4, a percentage reported as inhibition, in the whole organism at one dose (the size of the read-out at that dose, not a potency): 46.6%
Compound 4: the middle estimate sits 11.6 percentage points below what was measured, within the range that was stated.
By their numbers in this assay, from the lowest: compounds 2, 4 and 3 (each within the scatter of the next); then compound 1.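

In this assay, exchanging hydroxy for isopropyl on this aromatic carbon, para to a large group, gives a number 4.3 percentage points higher from compound 2 to compound 4 (within the scatter), so compound 4 cannot be told apart from compound 2. The earlier compounds shown here all carried oxygen-bearing groups on the ring, and compound 4 shows that a purely carbon group at this place, with no hydrogen-bond donor or acceptor, still gives a read-out in the same range as compound 2. Nothing measured here bears on why the exchange leaves the read-out within the scatter.

The compounds shown leave open how an amine, a carboxylic acid or a longer carbon chain would fare at this place. They also leave open whether adding methoxy to the ring of compound 4 would raise the read-out, as the step between compound 2 and compound 1 might suggest.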